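Cyclohexyl in place of ethyl on compound 3

The compounds below may be only part of what the source reports. "The series", "measured", "known", "first", "only" and "open" are said of these compounds alone.

Values measured in an ADME assay on microsomes from liver (Rattus norvegicus) for metabolic stability, read by HPLC, using NADPH, tested at 40 mM, in the presence of a further agent that is not named here (on this read-out lower numbers stand for a shorter-lived compound and higher numbers for a longer-lived compound), are as follows.
- Compound 1 (`CCOC(=O)/C(C#N)=C/c1ccc(O)c(O)c1`) gives a limit (< 0.0667 h)
- Compound 2 (`N#C/C(=C\c1ccc(O)c(O)c1)C(=O)OC1CCCCC1`) gives a number (0.417 h)
- Compound 3 (`CCOC(=O)/C(C#N)=C/c1ccoc1`) gives a limit (< 0.0667 h)

Compound 3 has no measured number, only a limit (< 0.0667 h). It shares that limit with compound 1 (the limit of < 0.0667 h in this assay, at which 2 of the 3 values shown sit). Compound 4 (`N#C/C(=C\c1ccoc1)C(=O)OC1CCCCC1`) departs from compound 3 by a single change (cyclohexyl in place of ethyl on an oxygen next to a carbonyl group), which is cyclohexyl in place of ethyl on an oxygen next to a carbonyl group.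

Within the data shown here, one measured step bears on this change. The same exchange on the core of compound 1 gave a clear rise (an at least 6.2-fold higher number from compound 1 to compound 2 (0.79 log units; beyond the scatter)). Going by these compounds, that step starts from the limit of compound 1, so its full size is unknown. It ends at a measured number for compound 2 (0.417 h). Among the measured compounds shown here, it is the only such pair, and its core differs from that of compound 3, so the transfer is uncertain and compound 4 may yet remain at the limit.

In this assay a rise beyond the scatter, of similar size, is nonetheless expected (an at least 4.4-fold higher number from compound 3 to compound 4 (0.65 log units; beyond the scatter)). The half-life estimated for compound 4 is 0.3 h (expected range 0.07 h to 1 h).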

Compound 4, half-life: 0.417 h
For compound 4 the middle estimate is 1.4-fold (0.14 log units) below the measured one; the measured number falls inside the stated range.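

In this assay, the exchange of ethyl for cyclohexyl on an oxygen next to a carbonyl group now yields a measured number on a second core, with an at least 6.2-fold higher number from compound 3 to compound 4 (0.79 log units; beyond the scatter). The rise is therefore no longer confined to the core of compound 1, and it appears on both cores shown: the same change on two cores in this assay, an at least 6.2-fold higher number (0.79 log units; beyond the scatter) from compound 1 to compound 2 and an at least 6.2-fold higher number (0.79 log units; beyond the scatter) from compound 3 to compound 4; the limit leaves it open whether they differ With cyclohexyl in place, compound 2 gives 0.417 h and compound 4 gives 0.417 h, so the two cores print the same half-life and the change between them shows no separation in this pair.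

Going by these compounds, compound 3 gives < 0.0667 h, which is a limit and not a number, so the full size of the rise on this core remains open. The compounds shown also leave open what a longer chain such as butyl, or another ring such as cyclopentyl, would give on that oxygen, and whether the two cores would still print the same half-life with such a group.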